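Changing the aryl on the triazole of an inactive core

The source may report more compounds than this note shows. Statements on the series, on what has been measured and on what is new or still open speak of the compounds shown alone.

Compound 3 `Cc1ccccc1-n1nncc1CN1C(=O)C2(C(C#N)=C(N)Oc3c(N)cc4nc5ccccc5nc4c32)c2ccccc21` was tested in a functional assay on HCT-116 cells (Homo sapiens) for antiproliferative activity, read by MTT assay, with a stated time of 48 h; a lower number here means a stronger inhibitor, a higher number a weaker inhibitor. In this assay compound 3 gives > 50000 nM, which is a limit of the assay and not a number. Its two relatives tell the same story. Compound 1 `Cc1ccccc1-n1nncc1CN1C(=O)C2(C(C#N)=C(N)Oc3c2c2nc4ccccc4nc2c2ccccc32)c2ccccc21` gives > 50000 nM in this assay, again a limit. Compound 2 `N#CC1=C(N)Oc2c(c3nc4ccccc4nc3c3ccccc23)C12C(=O)N(Cc1cnnn1-c1ccc(F)c(Cl)c1)c1ccccc12` gives > 50000 nM in this assay, also a limit. Among the compounds with values here, the only single change among them, a step that the two limits leave unreadable from compound 1 to compound 2, therefore cannot be sized, and all three results sit at the limit of > 50000 nM in this assay, at which 3 of the 3 values shown sit.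

Compound 4 `N#CC1=C(N)Oc2c(N)cc3nc4ccccc4nc3c2C12C(=O)N(Cc1cnnn1-c1cccc(C(F)(F)F)c1)c1ccccc12` differs from compound 3 by 3-(trifluoromethyl)phenyl in place of 2-methylphenyl on an aromatic nitrogen. Within the data shown here, since the one comparable swap, a step that the two limits leave unreadable from compound 1 to compound 2, gave no readable size, compound 4 is expected to remain at the limit, with the step that the limit leaves unreadable from compound 3 to compound 4 expected to be unreadable. The estimate for compound 4 is 60000 nM, ranging from 20000 nM to 200000 nM.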

Compound 4, half-maximal inhibitory concentration: 18900 nM
The estimate for compound 4 lay 3.2-fold (0.50 log units) above the measured number, and the stated range ends above it.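

In this assay, the aryl group on the triazole proves able to move a compound off the limit: 3-(trifluoromethyl)phenyl in place of 2-methylphenyl gives an at least 2.6-fold lower number from compound 3 to compound 4 (0.42 log units; beyond the scatter). The earlier aryl swap could not show this, since its step cannot be read. Compound 4 is the only compound here with a readable number, and the others stay at the limit: the limit of > 50000 nM in this assay, at which 3 of the 4 values shown sit.

On these data alone, it remains open whether the trifluoromethyl group itself or its ring position matters. A 3-methylphenyl or 2-(trifluoromethyl)phenyl group on the same nitrogen would help separate the two.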